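Fluoro for hydrogen on compound 2: expected effect

This account rests on a few compounds, and the source may have more. Where it says the series, first, only, none or still open, it means among the compounds named here.

Three compounds of the series have numbers in a functional assay on CHO cells for positive allosteric modulation of metabotropic glutamate receptor 2 (Homo sapiens), read by scintillation counting and GTPgammaS binding, with a stated time of 30 min; a higher number here means that more compound is needed for the effect, a lower number that less compound is needed. Compound 1 `Cc1cc(Oc2ccc(-c3ccn(CCC(C)C)c(=O)c3C#N)cc2)ccn1` gives 447 nM. Compound 2 `CCCCn1ccc(-c2ccc(Oc3ccnc(C)c3)cc2)c(C#N)c1=O` gives 398 nM, the lowest of the three, though compound 1 stands within the scatter of it. Compound 3 `Cc1cc(Oc2ccc(-c3ccn(CC4CC4)c(=O)c3C#N)cc2)ccn1` gives 832 nM, the furthest from compound 2. The steps measured so far all concern the chain on the ring nitrogen of the shared core: a 1.1-fold lower number from compound 1 to compound 2 (0.05 log units; within the scatter), a 1.9-fold higher number from compound 1 to compound 3 (0.27 log units; within the scatter) and a 2.1-fold higher number from compound 2 to compound 3 (0.32 log units; beyond the scatter). Compound 4 `CCCCn1ccc(-c2ccc(Oc3ccnc(C)c3)cc2F)c(C#N)c1=O` differs from compound 2 at another place: fluoro in place of hydrogen on an aromatic carbon. Among the measured compounds shown here, no measured step touches the aromatic ring that carries the new fluorine, so none of the three steps bears directly on this change; the steps on the chain were small, and nothing shows this ring to be more sensitive. The expectation in this assay is therefore a step of no more than the scatter, a 1.0-fold higher number from compound 2 to compound 4 (0.00 log units; within the scatter), in either direction. For the measured compounds named here, compound 4 is expected at 400 nM, with a range from 150 nM to 1100 nM, the width reflecting that no measured step informs this change.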

Compound 4, half-maximal effective concentration: 390 nM
Estimate against measurement, compound 4: 1.0-fold (0.01 log units) above, and the stated range covers the measured number.
By their numbers in this assay, from the lowest: compounds 4, 2, 1 and 3 (each within the scatter of the next, the first and the last beyond it).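

In this assay fluoro in place of hydrogen on an aromatic carbon gives a 1.0-fold lower number from compound 2 to compound 4 (0.01 log units; within the scatter) and so stays within the scatter. Among the compounds shown here, the earlier compounds spoke only to the chain on the ring nitrogen, whereas compound 4 gives the first reading on the six-membered aromatic ring of carbon only, at a place ortho to a large group and meta to the (2-methylpyridin-4-yl)oxy group. This position therefore takes a fluorine with the chain of compound 2 in place and without a step beyond the scatter, although nothing at hand gives a measured property or other evidence that could account for this result.

On these data alone, the reading rests on a single substituent at a single place, so it remains open whether chloro, methoxy, an amine or a carboxylic acid at this carbon would stay within the scatter as well, and whether the other carbons of this ring would behave alike. As far as these compounds go, it also remains open whether fluoro here would read the same with the isobutyl-bearing chain of compound 1 or the cyclopropyl-bearing chain of compound 3 on the ring nitrogen.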